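The compounds below may be only part of what the source reports. "The series", "measured", "known", "first", "only" and "open" are said of these compounds alone.

Measured compounds:
compound 1 `Cc1ccc(-c2nn(-c3ccccc3)cc2C(=O)Nc2ccccc2)cc1`: 2450 nM
compound 2 `O=C(Nc1ccccc1)c1cn(-c2ccccc2)nc1-c1ccc(Cl)cc1`: 2340 nM
compound 3 `O=C(Nc1ccc(Cl)cc1)c1cn(-c2ccccc2)nc1-c1ccc(Cl)cc1`: 3750 nM

In a functional assay on MCF7 cells (Homo sapiens) for cytotoxicity, read by MTT assay, with a stated time of 48 h (on this read-out higher numbers stand for weaker inhibition and lower numbers for stronger inhibition), compound 2 gives 2340 nM, and the other two numbers both sit within the scatter of it: the step of a 1.0-fold lower number from compound 1 to compound 2 (0.02 log units; within the scatter) and the step of a 1.6-fold higher number from compound 2 to compound 3 (0.20 log units; within the scatter) are each within the scatter. Compound 4 `O=C(Nc1ccccc1)c1cn(-c2ccccc2)nc1-c1ccc([N+](=O)[O-])cc1` differs from compound 2 by nitro in place of chloro on an aromatic carbon. Among the measured compounds shown here, no measured step exchanges a chloro for a nitro. For the measured compounds named here, the only step that alters this same ring, a 1.0-fold lower number from compound 1 to compound 2 (0.02 log units; within the scatter), stayed within the scatter, and the step of a 1.6-fold higher number from compound 2 to compound 3 (0.20 log units; within the scatter) on the other ring did too. On that basis the change a 1.1-fold higher number from compound 2 to compound 4 (0.05 log units; within the scatter) is expected to stay within the scatter. Compound 4 is therefore estimated at 2600 nM, with a range from 1200 nM to 5500 nM.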

Compound 4, half-maximal inhibitory concentration: 2260 nM
Compound 4: the middle estimate sits 1.2-fold (0.06 log units) above what was measured; the measured number falls inside the stated range.
By their numbers in this assay, from the lowest: compounds 4, 2, 1 and 3 (each within the scatter of the next).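

In this assay the change from 4-chlorophenyl to 4-nitrophenyl gives a 1.0-fold lower number from compound 2 to compound 4 (0.02 log units; within the scatter) and the exchange of methyl for nitro gives a 1.1-fold lower number from compound 1 to compound 4 (0.04 log units; within the scatter) at the same place. This position, para to a large group, has now carried methyl, chloro and nitro, and even the larger nitro with its hydrogen-bond acceptors leaves the number within the scatter. No evidence is at hand on why these three compounds stay so close. As far as these compounds go, whether an amine or a carboxylic acid at this position would also stay within the scatter remains open.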